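The compounds below may be only part of what the source reports. "The series", "measured", "known", "first", "only" and "open" are said of these compounds alone.

Working notes on the silicon-linked series. Compound 1 `CCN(C/C=C/C#CC(C)(C)C)Cc1cccc(OC[Si](C)(C)c2ccc(Cl)cc2)c1` carries a chloro group on the aromatic ring attached to silicon; in a functional assay on liver (Sus scrofa) for inhibition of squalene monooxygenase (Homo sapiens), using microsomes (on this read-out lower numbers stand for stronger inhibition and higher numbers for weaker inhibition), compound 1 gives 400 nM. For the measured compounds named here, compound 2 `CCN(C/C=C/C#CC(C)(C)C)Cc1cccc(OC[Si](C)(C)c2ccc(S)cc2)c1` has sulfanyl in place of chloro on that aromatic carbon; in this assay compound 2 gives 8000 nM, the highest of the two numbers so far, separated from compound 1 by a 20-fold higher number from compound 1 to compound 2 (1.30 log units; beyond the scatter).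

Compound 3 `CCN(C/C=C/C#CC(C)(C)C)Cc1cccc(OC[Si](C)(C)Cc2ccccc2)c1` is the next case: benzyl in place of 4-sulfanylphenyl on a silicon. Going by the values given here, only one measured step bears on this change, the large one from compound 1 to compound 2, which shows how much the number moved when sulfanyl entered at this position. Compound 3 removes the sulfanyl again and drops the donor and acceptor with it, while the aromatic ring is kept and moved one saturated carbon away from silicon. The expectation for compound 3 is therefore a lower number than compound 2, with compound 2 giving 8000 nM as the reference point, estimated as an 11-fold lower number from compound 2 to compound 3 (1.06 log units; beyond the scatter). Compound 3 is expected to fall at 700 nM, within the range 150 nM to 3000 nM.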

Compound 3, half-maximal inhibitory concentration: 130 nM
Estimate against measurement, compound 3: 5.4-fold (0.73 log units) above; the measured number lies below the stated range.
By their numbers in this assay, from the lowest: compound 3; then compound 1; then compound 2.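

In this assay the group on silicon can change as a whole and the number still falls: benzyl in place of 4-sulfanylphenyl gives a 62-fold lower number from compound 2 to compound 3 (1.79 log units; beyond the scatter) and thus more than reverses the earlier rise. Benzyl in place of 4-chlorophenyl gives a 3.1-fold lower number from compound 1 to compound 3 (0.49 log units; beyond the scatter) and this modest step shows that compound 3 stands below the chloro compound as well as the sulfanyl compound. The earlier pair showed only a change of ring substituent, whereas compound 3 shows that a benzyl group with neither chloro nor sulfanyl gives the lowest number of the three. No measurement at hand accounts for either step.

Still open, on these data alone, is how much of these steps belongs to the saturated carbon and how much to the lost ring substituent. A plain phenyl or a 4-chlorobenzyl group on silicon would separate the two, and a 2-phenylethyl group would test a longer chain.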